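From 4-fluorobenzyl ether to ethyl ether on one core

This account rests on a few compounds, and the source may have more. Where it says the series, first, only, none or still open, it means among the compounds named here.

Compound 1 `CN(C)CCNc1ccnc2cc(OCc3ccc(F)cc3)ccc12`: 780 nM
Compound 2 `CN(C)CCCNc1ccnc2cc(OCc3ccc(F)cc3)ccc12`: 940 nM

In a functional assay on NCI-H1650 cells (Homo sapiens) for cytotoxicity, read by MTT assay, with a stated time of 48 h (on this read-out higher numbers stand for weaker inhibition and lower numbers for stronger inhibition), compound 1 gives 780 nM. Compound 2 gives 940 nM. Of these two numbers that of compound 1 is the smaller, yet the step of a 1.2-fold higher number from compound 1 to compound 2 (0.08 log units; within the scatter) is within the scatter, so the two compounds cannot be told apart on this read-out.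

Compound 3 `CCOc1ccc2c(NCCN(C)C)ccnc2c1` has not been measured. It differs from compound 1 by methyl in place of 4-fluorophenyl on a saturated chain carbon bound to an oxygen on an aromatic ring; the same difference, cut one bond further out, reads 4-fluorobenzyl to ethyl. Among the measured compounds shown here, the only measured step, from compound 1 to compound 2, touches the amine chain, not the ether, so no measured step bears on this change, and the expectation rests on the structural change alone. Losing a whole aromatic ring is expected to weaken inhibition, so a step of a 3.8-fold higher number from compound 1 to compound 3 (0.59 log units; beyond the scatter) is estimated. Compound 3 is therefore expected at 3000 nM, within 800 nM to 12000 nM.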

Compound 3, half-maximal inhibitory concentration: 3490 nM
The estimate for compound 3 lay 1.2-fold (0.07 log units) below the measured number; the range from low to high includes it.
By their numbers in this assay, from the lowest: compounds 1 and 2 (each within the scatter of the next); then compound 3.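

Among the compounds shown here, until this point only the amine chain had changed, so this is the first view of what the ether end of the molecule contributes. In this assay, exchanging 4-fluorobenzyl for ethyl gives a 4.5-fold higher number from compound 1 to compound 3 (0.65 log units; beyond the scatter) and this modest step lies beyond the scatter, showing that the read-out responds to the group at this position and that the compound carrying the 4-fluorophenyl ring gives the lower number. No measurement shown here explains this difference.

Still open, from the compounds shown here alone, is whether the fluorine matters, or the ring itself, or simply a larger group at this position. An unsubstituted benzyl ether and a longer chain such as a hexyl ether on the shared core would help to separate these possibilities.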